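The compounds below may be only part of what the source reports. "The series", "measured", "known", "first", "only" and "open" are said of these compounds alone.

Compound 1, `Cc1ccc(S(=O)(=O)N2Cc3ccccc3OC[C@@H]2C)cc1`, in a functional assay on Ishikawa cells (Homo sapiens) for cytotoxicity, read by MTT assay, with a stated time of 18 h (on this read-out higher numbers stand for weaker inhibition and lower numbers for stronger inhibition), gives > 50000 nM, a limit of the assay and not a number.
Compound 2, `Cc1ccc(S(=O)(=O)N2Cc3ccccc3OC[C@@H]2C(C)C)cc1`, in this assay gives > 50000 nM, again a limit of the assay and not a number.

Compound 2 thus stands at a limit rather than at a measured number, as does the only other compound shown, and both values sit at the limit of > 50000 nM in this assay, at which 2 of the 2 values shown sit. Compound 3, `CCC(C)[C@H]1COc2ccccc2CN1S(=O)(=O)c1ccc(C)cc1`, has not yet been measured in this assay. It differs from compound 2 by methyl in place of hydrogen on a saturated chain carbon, two bonds along the chain from a saturated ring carbon. Within the data shown here, the only measured step, a step that the two limits leave unreadable from compound 1 to compound 2, is left unreadable by the two limits, so its size is unknown. With no readable step to draw on, no change beyond the scatter is expected in this assay for compound 3. Compound 3 is therefore expected to remain at the limit, a step that the limit leaves unreadable from compound 2 to compound 3 from its neighbour. Compound 3 is estimated at 60000 nM, within 20000 nM to 300000 nM.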

Compound 3, half-maximal inhibitory concentration: > 50000 nM
Compound 3: only a limit was reported; the forecaster's own chance of this, stated with the estimate: 85%; the middle value does not contradict the limit.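

Compound 3 gives > 50000 nM in this assay, a limit of the assay and not a number, so neither step to compound 3, from compound 1 or from compound 2, can be read. The compounds shown leave open where the true value of each lies and whether changing this group has any effect in this assay.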